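Chloro to bromo on a fused two-ring core

The source may hold more compounds than are shown below. What is called first, only, known or untested is meant among the compounds shown, and "the series" means these compounds.

compound 1 `Cc1cc(C)n2nccc2n1`: 79 mg/kg
compound 2 `Cc1cc(C)n2ncc(Cl)c2n1`: 38.6 mg/kg

In a functional assay on the whole organism with Rattus norvegicus as the target (on this read-out lower numbers stand for an effect already at smaller amounts and higher numbers for an effect only at larger amounts of compound), compound 2 gives 38.6 mg/kg, the lower of the two numbers; compound 1 gives 79 mg/kg. Compound 3 `Cc1cc(C)n2ncc(Br)c2n1` differs from compound 2 by bromo in place of chloro on an aromatic carbon. Within the data shown here, the one measured step, a 2.0-fold lower number from compound 1 to compound 2 (0.31 log units; beyond the scatter), exchanged hydrogen for chloro; one halogen for another is a smaller change, and nothing measured here shows its effect, so no step beyond the scatter is foreseen. Compound 3 is therefore expected to give 32 mg/kg, between 16 mg/kg and 65 mg/kg. The expected step, a 1.2-fold lower number from compound 2 to compound 3 (0.08 log units; within the scatter), stays within the scatter.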

Compound 3, dose for half-maximal effect: 27.1 mg/kg
For compound 3 the middle estimate is 1.2-fold (0.07 log units) above the measured one; low and high end bracket the measured number.
By their numbers in this assay, from the lowest: compounds 3 and 2 (each within the scatter of the next); then compound 1.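

On an aromatic carbon of the five-membered ring, bromo in place of chloro gives a 1.4-fold lower number from compound 2 to compound 3 (0.15 log units; within the scatter) in this assay and so does not separate the two halogens. Bromo in place of hydrogen gives a 2.9-fold lower number from compound 1 to compound 3 (0.46 log units; beyond the scatter) on the same read-out, so a second halogen at this place also stands apart from compound 1. Nothing available explains these numbers. The compounds shown leave open whether iodo, or a group of another kind such as an amine or a nitrile, would fit this pattern at the same place.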